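The compounds below may be only part of what the source reports. "The series", "measured", "known", "first", "only" and "open" are said of these compounds alone.

Working notes on the series. In a functional assay on HEL cells (Homo sapiens) (a lower number here means that less compound is tolerated, a higher number that more compound is tolerated), compound 2 `CC(=O)NC1=CS(=O)(=O)O[C@@]12[C@@H](CO[Si](C)(C)C(C)(C)C)O[C@@H](n1cc(C)c(=O)n(C)c1=O)[C@@H]2O[Si](C)(C)C(C)(C)C` reads > 200000 nM. That value is a limit of the assay and not a number. Compound 3 `Cc1cn([C@@H]2O[C@@H]3COC(=O)[C@]3(OS(C)(=O)=O)[C@H]2O)c(=O)[nH]c1=O` reads >= 36000 nM, which is also a limit. Compound 1 `Cc1cn([C@@H]2O[C@H](CO[Si](C)(C)C(C)(C)C)[C@@]3(OS(=O)(=O)C=C3NCC(N)=O)[C@H]2O[Si](C)(C)C(C)(C)C)c(=O)n(C)c1=O` is the only one of the three with a plain number, at 13500 nM. From the compounds shown here alone, compound 2 therefore stands at the tolerated end of what has been measured, but its true position is unknown.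

Compound 4 `COC(=O)NC1=CS(=O)(=O)O[C@@]12[C@@H](CO[Si](C)(C)C(C)(C)C)O[C@@H](n1cc(C)c(=O)n(C)c1=O)[C@@H]2O[Si](C)(C)C(C)(C)C` follows from compound 2 by methoxy in place of methyl on a carbonyl carbon, with methoxy in place of methyl on a carbonyl carbon. Going by the values given here, the one measured step that bears on this is an at least 14-fold higher number from compound 1 to compound 2 (1.17 log units; beyond the scatter), with acetyl in place of carbamoylmethyl on an amine nitrogen. That step was large, but it is a different change from this one, and compound 4 keeps the carbonyl on nitrogen found in compound 2. No step beyond the scatter is therefore expected in this assay, although any real movement could only be seen as a fall from the limit. The estimated step is an at least 1.2-fold lower number from compound 2 to compound 4 (0.09 log units; that floor lies within the scatter). For compound 4 the estimated value is 160000 nM, with an expected range of 40000 nM to 300000 nM.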

Compound 4, half-maximal cytotoxic concentration: > 200000 nM
Compound 4 gave a limit, no number (the forecaster's own chance of this, stated with the estimate: 55%); at least 1.2-fold (0.09 log units) between middle value and limit.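

The step from compound 2 to compound 4 cannot be read, because both compounds stand at one limit: the limit of > 200000 nM in this assay, at which 2 of the 4 values shown sit.

What compound 4 adds is a second group on the amine nitrogen that departs from compound 1 in the same way as acetyl: methoxycarbonyl in place of carbamoylmethyl gives an at least 14-fold higher number from compound 1 to compound 4 (1.17 log units; beyond the scatter), a step beyond the scatter, to be set beside an at least 14-fold higher number from compound 1 to compound 2 (1.17 log units; beyond the scatter). Among these three compounds, which differ in one place, the two with a carbonyl bonded to the amine nitrogen therefore read as limits in this assay, and only carbamoylmethyl gives a plain number.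

From the compounds shown here alone, the true values of compound 2 and compound 4 remain unknown, so it stays open whether acetyl and methoxycarbonyl differ at all on this nitrogen. Also open, going by these compounds, is how a longer chain such as propanoyl, or a carboxylic acid such as carboxymethyl, would read at this position in this assay.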